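A few compounds are considered here, and "the series" means these few. Any claim that something is new, unique, unknown or untested is made for them only; others in the source may bear on it.

Compound 1 `COc1cc(-n2ncnc2-c2ccc(C)cc2)cc(OC)c1OC`: 90 nM
Compound 2 `COc1cc(-c2ncnn2-c2cccc(N)c2)cc(OC)c1OC`: > 10000 nM, a limit of the assay and not a number

Going by the values given here, in a functional assay on HL-60 cells (Homo sapiens) for antiproliferative activity, read by MTT assay, with a stated time of 72 h (on this read-out higher numbers stand for weaker inhibition and lower numbers for stronger inhibition), compound 1 gives 90 nM, the only actual number so far, so it has no measured neighbour to be ranked against. Compound 3 `COc1cc(-n2ncnc2-c2ccc(Cl)c(Cl)c2)cc(OC)c1OC` has 3,4-dichlorophenyl in place of 4-methylphenyl on an aromatic carbon. Among the compounds with values here, no measured step covers this change, so the expectation starts from compound 1 at 90 nM and is loose. A moderate move towards weaker inhibition is expected, estimated as a 5.6-fold higher number from compound 1 to compound 3 (0.74 log units; beyond the scatter). For compound 3 the estimated value in this assay is 500 nM, with an expected range of 90 nM to 3500 nM.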

Compound 3, half-maximal inhibitory concentration: > 10000 nM
Compound 3: a limit, no number (the forecaster's own chance of this, stated with the estimate: 12%); middle value at least 20-fold (1.30 log units) away from the limit.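

In this assay, 3,4-dichlorophenyl in place of 4-methylphenyl on an aromatic carbon gives an at least 110-fold higher number from compound 1 to compound 3 (2.04 log units; beyond the scatter). Going by these compounds alone, this is the first sign that the group at this position can decide whether any inhibition is seen within the tested range, even though the entering and leaving groups match in ring type and in the counts of donors and acceptors. The value of compound 3 is a limit of the assay and not a number, so the true size of the step stays open: the limit of > 10000 nM in this assay, at which 2 of the 3 values shown sit.

From the compounds shown here alone, whether one chlorine alone is enough for this loss remains open. A 4-chlorophenyl or 4-methoxyphenyl group at this position would help to separate the two chlorine atoms' contributions.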